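Working notes: compound 2 to its alkynyl ester, compound 4

The source may report more compounds than this note shows. Statements on the series, on what has been measured and on what is new or still open speak of the compounds shown alone.

Compound 1 (`CCN(CC)CCNC(=O)c1ccc(C(CC)(CC)c2ccc(OCCC(O)(CC)CC)c(C)c2)n1CC`), compound 2 (`CCn1c(C(=O)NCCN)ccc1C(CC)(CC)c1ccc(OCCC(O)(CC)CC)c(C)c1`) and compound 3 (`CCn1c(C(=O)N(CCC#N)CCC#N)ccc1C(CC)(CC)c1ccc(OCCC(O)(CC)CC)c(C)c1`) differ only in the group on the carbonyl carbon. In a functional assay on MCF7 cells (Homo sapiens) for antiproliferative activity, read by MTT assay, with a stated time of 48 h (on this read-out lower numbers stand for stronger inhibition and higher numbers for weaker inhibition), compound 1 gives 550 nM and compound 2 gives 670 nM as values that stand within the scatter of each other. Compound 3 gives > 50000 nM in this assay and this is a limit, not a number.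

Compound 4 (`C#CC(C)OC(=O)c1ccc(C(CC)(CC)c2ccc(OCCC(O)(CC)CC)c(C)c2)n1CC`) carries (1-methylprop-2-yn-1-yl)oxy in place of (2-aminoethyl)amino on a carbonyl carbon.

Changes at this carbonyl carbon have gone both ways: a 1.2-fold higher number from compound 1 to compound 2 (0.09 log units; within the scatter) stays within the scatter, while an at least 90-fold higher number from compound 1 to compound 3 (1.95 log units; beyond the scatter) and an at least 74-fold higher number from compound 2 to compound 3 (1.87 log units; beyond the scatter) are both large. Within the data shown here, compound 3 is the only measured compound without a chain ending in an amino group, and compound 4 also lacks one, so the large steps weigh most. No ester has been measured, so the expectation stays broad. A large rise, a 7.5-fold higher number from compound 2 to compound 4 (0.87 log units; beyond the scatter) as estimated, is expected in this assay and would mean weaker inhibition. For compound 4 the estimated value is 5000 nM (800 nM to 50000 nM), an expectation only.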

Compound 4, half-maximal inhibitory concentration: > 50000 nM
Compound 4: only a limit was reported; the forecaster's own chance of this, stated with the estimate: 35%; middle value at least 10-fold (1.00 log units) away from the limit.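

In this assay, the (1-methylprop-2-yn-1-yl)oxy group on the carbonyl carbon shows that an ester can lose the activity of the amides, with an at least 74-fold higher number from compound 2 to compound 4 (1.87 log units; beyond the scatter) and an at least 90-fold higher number from compound 1 to compound 4 (1.95 log units; beyond the scatter). Compound 4 gives > 50000 nM, and this is a limit, not a number. Compound 3 and compound 4, the two measured compounds without a chain ending in an amino group, now stand together at the top of the range: the limit of > 50000 nM in this assay, at which 2 of the 4 values shown sit.

The step between compound 3 and compound 4 cannot be read, as both values are limits. From the compounds shown here alone, compound 4 changes both the atom bonded to the carbonyl carbon and the chain end relative to compound 2, so it remains open which change matters; a 2-aminoethyl ester, or an amide carrying the 1-methylprop-2-yn-1-yl group, would separate the two.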